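Swapping an anilide for a dichlorophenyl ester on the chain

This account rests on a few compounds, and the source may have more. Where it says the series, first, only, none or still open, it means among the compounds named here.

Compound 1 `CC(C)COc1ccc(NC(=O)CCCCCCCSc2nnc(Cc3nn(C)c(=O)c4ccccc34)n2C)cc1` gives 4800 nM in an assay on isolated protein (Mus musculus) for inhibition of IL15-IL15 receptor (Homo sapiens), read by resazurin assay, with stated times of 30 min and 2.5 days; on this read-out higher numbers stand for weaker inhibition and lower numbers for stronger inhibition.
Compound 2 `Cn1c(Cc2nn(C)c(=O)c3ccccc23)nnc1SCCCCCCCCCCC(=O)Nc1ccccc1Cl` gives 15000 nM in this assay.
Compound 3 `Cn1c(Cc2nn(C)c(=O)c3ccccc23)nnc1SCC(=O)Nc1ccc(Cl)cc1Cl` gives 17300 nM in this assay.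

All three compounds share the same core, joined through a sulfur-linked chain to an amide bearing an aromatic ring. Among them compound 1 holds the lowest number, and its distance to compound 2 and to compound 3 lies beyond the scatter of repeated measurements, so compound 1 is the strongest inhibitor of the three.

Compound 4 `Cn1c(Cc2nn(C)c(=O)c3ccccc23)nnc1SCCCCCCCC(=O)Oc1ccc(Cl)cc1Cl` has not been measured. It departs from compound 1 by one change: 2,4-dichlorophenoxy in place of (4-(isobutoxy)phenyl)amino on a carbonyl carbon. Among the compounds with values here, no pair of measured compounds isolates this change, so its effect cannot be read from the numbers at hand. Compound 3, which also carries a dichlorinated ring at the chain end, gives 17300 nM, and the loss of the amide hydrogen adds further uncertainty. A step toward weaker inhibition, beyond the scatter, is expected from compound 1 to compound 4 a 2.5-fold higher number from compound 1 to compound 4 (0.40 log units; beyond the scatter). Compound 4 is estimated at 12000 nM, within a range from 4000 nM to 40000 nM.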

Compound 4, half-maximal inhibitory concentration: 800 nM
Compound 4: middle estimate off by 15-fold (1.18 log units), on the high side; measured number outside the range, below it.
By their numbers in this assay, from the lowest: compound 4; then compound 1; then compounds 2 and 3 (each within the scatter of the next).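

The change from (4-(isobutoxy)phenyl)amino to 2,4-dichlorophenoxy on a carbonyl carbon gives a 6.0-fold lower number from compound 1 to compound 4 (0.78 log units; beyond the scatter) in this assay, so inhibition gets stronger and a single change at this end of the chain can shift the result by more than the scatter. The entering group has no hydrogen-bond donor where the leaving group has one, so that donor is not needed for inhibition at this level. Nothing available accounts for the gain.

This one step alters both the linking atom and the ring substituents, so it leaves open which of the two matters. A 2,4-dichlorophenylamino group or a 4-(isobutoxy)phenoxy group on the same carbonyl carbon would separate them, while a free carboxylic acid there would show whether the aromatic ring is needed at all.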